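The source may report more compounds than this note shows. Statements on the series, on what has been measured and on what is new or still open speak of the compounds shown alone.

Three close relatives built on a shared core have been measured in a functional assay on SF-295 cells (Homo sapiens) for cytotoxicity, read by sulforhodamine B assay, with a stated time of 48 h; a lower number here means that less compound is tolerated, a higher number that more compound is tolerated. Compound 1 `ClCc1cccc(Cn2cnc3c(Cl)nc(Cl)nc32)c1` gives 45700 nM. Compound 2 `Nc1nc(Cl)c2ncn(Cc3ccccc3CCl)c2n1` gives 63100 nM in this assay. Compound 3 `ClCc1ccccc1Cn1cnc2nc(Cl)nc(Cl)c21` gives 61700 nM in this assay, a number that sits within the usual scatter of both compound 1 and compound 2, so the three cannot be told apart on these numbers. The next compound is compound 4 `ClCc1ccccc1Cn1cnc2ncnc(Cl)c21`, which has not yet been measured in this assay. Compound 4 differs from compound 3 in a single place: hydrogen in place of chloro on an aromatic carbon. Among the measured compounds shown here, no measured pair shows this same change, so there is nothing to lean on beyond the three numbers, all of which lie close together. The expected step is a 1.1-fold higher number from compound 3 to compound 4 (0.02 log units; within the scatter), that is, no change beyond the scatter, although a modest weakening cannot be ruled out. In this assay compound 4 is therefore estimated at 65000 nM, with a range from 30000 nM to 140000 nM.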

Compound 4, concentration lethal to 50% of the cells: 46800 nM
Compound 4: the middle estimate sits 1.4-fold (0.14 log units) above what was measured, within the range that was stated.
By their numbers in this assay, from the lowest: compounds 1, 4, 3 and 2 (each within the scatter of the next).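

In this assay, putting hydrogen in place of the chloro on the aromatic carbon between two ring nitrogen atoms gives a 1.3-fold lower number from compound 3 to compound 4 (0.12 log units; within the scatter). Among the compounds shown here, this is the first pair of compounds here that differ in one place, and it shows that losing this chloro leaves the number inside the usual scatter. Nothing measured here offers a reason for this result.

One swap at one position cannot show how other groups would behave there, so a methyl, a methoxy group or a nitrile on that carbon remains an open case. The compounds shown also leave open what happens to the number when the remaining chloro on the ring, or the chloromethyl group, is replaced by hydrogen.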